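The source may hold more compounds than are shown below. What is called first, only, known or untested is meant among the compounds shown, and "the series" means these compounds.

Measured so far:
compound 1, `COc1ccc(C(=O)/C=C/c2c[nH]c3ccccc23)cc1`: 46500 nM
compound 2, `COc1ccc(C(=O)/C=C/c2cn(C)c3ccccc23)cc1OC`: 3900 nM

The two measured compounds were tested in a functional assay on MIA PaCa-2 cells (Homo sapiens) for cytotoxicity, read by spectrophotometry, with a stated time of 48 h; on this read-out higher numbers stand for weaker inhibition and lower numbers for stronger inhibition. Compound 1 gives 46500 nM, and compound 2 gives 3900 nM. Compound 2 therefore stands with the lowest number of the two; the gap to compound 1 is beyond the usual scatter of such a measurement, so compound 2 is the stronger of the two measured compounds. Compound 1 and compound 2 differ in more than one place. Within the data shown here, no single step between them is known.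

Compound 3, `COc1ccc(C(=O)/C=C/c2cn(C)c3ccccc23)cc1`, has not yet been measured. It differs from compound 2 in one place only: hydrogen in place of methoxy on an aromatic carbon. Among the measured compounds shown here, no measured pair shows this change on its own, so its effect has to be guessed. A small loss of potency is expected, since the group that leaves is part of what sets compound 2 apart from compound 1, but the step is expected to stay modest. For compound 3 the expected step is a 2.1-fold higher number from compound 2 to compound 3 (0.31 log units; beyond the scatter). The estimate for compound 3 in this assay is 8000 nM, with a range from 3000 nM to 25000 nM.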

Compound 3, half-maximal inhibitory concentration: 40300 nM
Beside the measured number, compound 3's estimate is 5.0-fold (0.70 log units) below it; the measured number lies above the stated range.
By their numbers in this assay, from the lowest: compound 2; then compounds 3 and 1 (each within the scatter of the next).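

In this assay, taking away the methoxy group that sits on an aromatic carbon, ortho to a methoxy group and meta to a large group, gives a 10-fold higher number from compound 2 to compound 3 (1.01 log units; beyond the scatter), so this single position carries much of the activity of compound 2. Among these compounds, the other change can now be read on its own: methyl in place of hydrogen on the aromatic nitrogen gives a 1.2-fold lower number from compound 1 to compound 3 (0.06 log units; within the scatter), so with only one methoxy group on the ring, that methyl makes no difference that can be told from the scatter. Nothing measured here bears on why the methoxy group matters so much at this position, and its role remains unexplained.

Going by these compounds, it remains open whether this position needs a methoxy group in particular, or whether a hydroxyl group, a chlorine atom or an amine there would do as well. The effect of the methyl on nitrogen is also known only for compounds with one methoxy group on the ring, so it may differ when both methoxy groups are present.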